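The source may hold more compounds than are shown below. What is called first, only, known or untested is meant among the compounds shown, and "the series" means these compounds.

In an in vitro ADME assay on microsomes from liver (Simiiformes) (a higher number here means that the compound lasts longer, a lower number that the compound disappears faster), the measured compounds are:
Compound 1 `Cc1cc(CCCOc2c(C)cc(-c3noc(CC(F)(F)F)n3)cc2C)on1`: 0.533 h
Compound 2 `Cc1cc(CCCOc2c(C)cc(-c3noc(C(N)=O)n3)cc2C)on1`: 2.3 h

Compound 2, at 2.3 h, holds the higher of the two numbers. Compound 3 `Cc1cc(CCCOc2c(C)cc(-c3noc(C(Cl)(Cl)Cl)n3)cc2C)on1` has trichloromethyl in place of carbamoyl on an aromatic carbon. Within the data shown here, one measured step bears on this, at a carbon with the same surroundings: a 4.3-fold higher number from compound 1 to compound 2 (0.64 log units; beyond the scatter). It also brought in carbamoyl, there replacing 2,2,2-trifluoroethyl. Taking carbamoyl out again should therefore give a step of similar size in this assay, towards a lower number. The expected change is a 3.3-fold lower number from compound 2 to compound 3 (0.52 log units; beyond the scatter). For compound 3 the estimated half-life is 0.7 h, with an expected range of 0.2 h to 2 h.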

Compound 3, half-life: 0.183 h
For compound 3 the middle estimate is 3.8-fold (0.58 log units) above the measured one; measured number outside the range, below it.
By their numbers in this assay, from the lowest: compound 3; then compound 1; then compound 2.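

Among these compounds, at this carbon of the five-membered aromatic ring, the choice of group matters more in this assay than the one earlier step showed: carbamoyl gives way to trichloromethyl with a 13-fold lower number from compound 2 to compound 3 (1.10 log units; beyond the scatter). The two groups without carbamoyl also differ from each other beyond the scatter, with a 2.9-fold lower number from compound 1 to compound 3 (0.46 log units; beyond the scatter), so 2,2,2-trifluoroethyl and trichloromethyl are not interchangeable here. Nothing available accounts for this order of the three groups. Still open, on these data alone, is how an amine, a carboxylic acid or a nitrile at this carbon would compare with carbamoyl. As far as these compounds go, whether the same order holds on another core also remains open.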